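A few compounds are considered here, and "the series" means these few. Any claim that something is new, unique, unknown or untested is made for them only; others in the source may bear on it.

In an ADME assay on CEM-SS cells (Homo sapiens) for cytotoxicity, read by XTT assay, with a stated time of 6 days (on this read-out lower numbers stand for higher toxicity in this test and higher numbers for lower toxicity in this test), compound 3 `CCCC(=O)OCSc1ccccc1C(=O)NCC(=O)N(C)C` gives 38.3 uM. Compound 1 `CCCC(=O)OCSc1ccccc1C(=O)NCCCC(N)=O` gives 56.6 uM, within the scatter of that number. Compound 2 `CCCC(=O)OCSc1ccccc1C(=O)NCC(=O)NC` reads > 100 uM, which is a limit of the assay.

Compound 4 `CCCC(=O)OCSc1ccccc1C(N)=O` carries hydrogen in place of (dimethylcarbamoyl)methyl on an amide-type nitrogen. Within the data shown here, no measured step removes this whole side chain, so the guides are changes within it: an at least 1.7-fold higher number from compound 1 to compound 2 (0.24 log units; that floor lies within the scatter), a 1.5-fold lower number from compound 1 to compound 3 (0.17 log units; within the scatter) and an at least 2.6-fold lower number from compound 2 to compound 3 (0.41 log units; beyond the scatter), the last being the only one clearly beyond the scatter. On these data alone, with two of these three steps small and the third modest, no step beyond the scatter is expected, and the direction stays open. The expected step is a 1.3-fold higher number from compound 3 to compound 4 (0.12 log units; within the scatter). Compound 4 is estimated at 50 uM, with an expected range of 20 uM to 100 uM.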

Compound 4, half-maximal toxic concentration: 12.4 uM
Compound 4: middle estimate off by 4.0-fold (0.61 log units), on the high side; measured number outside the range, below it.
By their numbers in this assay, from the lowest: compound 4; then compounds 3 and 1 (each within the scatter of the next). At a limit, above all of these: compound 2.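

In this assay, hydrogen on the amide-type nitrogen, with no side chain at all, gives the lowest number of the four compounds (a 3.1-fold lower number from compound 3 to compound 4 (0.49 log units; beyond the scatter)) and (a 4.6-fold lower number from compound 1 to compound 4 (0.66 log units; beyond the scatter)). Among these compounds, at this position, then, each of the side chains reads higher than hydrogen, whereas the earlier steps compared only chains. The third step (an at least 8.0-fold lower number from compound 2 to compound 4 (0.90 log units; beyond the scatter)) is only a floor, set by a limit: the limit of > 100 uM in this assay, at which 1 of the 4 values shown sits.

On these data alone, all three side chains carry a carbamoyl group, so what the chain alone contributes stays open. A simple methyl on that nitrogen, or a chain ending in a carboxylic acid or an amine, would separate the two.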